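A few compounds are considered here, and "the series" means these few. Any claim that something is new, unique, unknown or untested is made for them only; others in the source may bear on it.

In a functional assay with Rattus norvegicus as the target (a higher number here means that more compound is needed for the effect, a lower number that less compound is needed), compound 1 (`CC(C)C(/N=C(\S)NCc1ccc(C(C)(C)C)cc1)c1ccc(NS(C)(=O)=O)cc1`) gives > 100000 nM, which is a limit of the assay and not a number. Compound 2 (`C[C@@H](/N=C(\S)NCc1ccc(C(C)(C)C)cc1)c1ccc(C(C)(C)C)cc1`) gives > 100000 nM, again a limit. Among the compounds with values here, compound 1 thus stands at the limit of > 100000 nM in this assay, at which 2 of the 2 values shown sit, so there is no exact number for it and no measured step between compounds to learn from.

Compound 3 (`CCC(/N=C(\S)NCc1ccc(C(C)(C)C)cc1)c1ccc(NS(C)(=O)=O)cc1`) keeps the core of compound 1 and changes one small group, isopropyl to ethyl: hydrogen in place of methyl on a saturated chain carbon bound to two saturated chain carbons. In words, this is hydrogen in place of methyl on a saturated chain carbon bound to two saturated chain carbons.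

Within the data shown here, with no measured step as a guide, no change beyond the usual scatter is expected in this assay, and no direction can be favoured. This expectation starts from compound 1 at > 100000 nM, a limit, and the change is a single carbon. The step of a number no higher from compound 1 to compound 3 (the limit leaves the size open) is expected to stay small. For compound 3 the expected value is 100000 nM, with an estimated range from 30000 nM to 200000 nM, and the assay may well report only a limit again.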

Compound 3, half-maximal effective concentration: > 100000 nM
Compound 3 ended at the assay's limit; the forecaster's own chance of this, stated with the estimate: 85%; the middle value lies on the limit itself.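

Within the data shown here, compound 3 gives > 100000 nM in this assay and this is a limit, not a number; compound 1 also sits at a limit, so the change from isopropyl to ethyl between compound 1 and compound 3 gives no step that can be read. The compounds shown leave open what exact value any of them would have, and whether any change to them would give a readable number: the limit of > 100000 nM in this assay, at which 3 of the 3 values shown sit.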